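The source may report more compounds than this note shows. Statements on the series, on what has been measured and on what is new or still open speak of the compounds shown alone.

Measured so far:
compound 1, `CC[C@H]1[C@@H](N)CN1c1cc2c(cc1F)c(=O)c(C(=O)O)cn2C1CC1`: 42.2 ug/mL
compound 2, `CN(C)C1(C)CN(c2c(F)cc3c(=O)c(C(=O)O)cn(C4CC4)c3c2F)C1`: 23.6 ug/mL

In a physicochemical assay for solubility, at pH 7.4 (on this read-out lower numbers stand for lower solubility and higher numbers for higher solubility), compound 2 gives 23.6 ug/mL, the lowest of the two numbers, while compound 1 gives 42.2 ug/mL in this assay, a gap that stays within the scatter of repeated measurements. Compound 3, `CC[C@H]1[C@@H](N)CN1c1c(F)cc2c(=O)c(C(=O)O)cn(C3CC3)c2c1F`, has not yet been measured in this assay. It differs from compound 2 as follows: a group of 7 heavy atoms (5 carbon, 2 nitrogen; one four-membered non-aromatic ring with 1 hetero atom) in place of a group of 8 heavy atoms (6 carbon, 2 nitrogen; one four-membered non-aromatic ring with 1 hetero atom), on an aromatic carbon The group that enters is the same one that compound 1 carries. For the measured compounds named here, no step between measured compounds is known here, so the step of a 1.4-fold higher number from compound 2 to compound 3 (0.13 log units; within the scatter) is expected to remain within the scatter, with no clear direction. Compound 3 is estimated at 32 ug/mL, in a range from 13 ug/mL to 80 ug/mL.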

Compound 3, solubility: 55.9 ug/mL
For compound 3 the middle estimate is 1.7-fold (0.24 log units) below the measured one; measured number inside the range.
By their numbers in this assay, from the lowest: compounds 2, 1 and 3 (each within the scatter of the next, the first and the last beyond it).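

In this assay, for the compounds shown here, the exchange of the 3-(dimethylamino)-3-methylazetidin-1-yl group for the group of compound 1, on the aromatic carbon ortho to two fluoro groups, gives the first step beyond the scatter (a 2.4-fold higher number from compound 2 to compound 3 (0.37 log units; beyond the scatter)). Fluoro in place of hydrogen on an aromatic carbon gives a step within the scatter (a 1.3-fold higher number from compound 1 to compound 3 (0.12 log units; within the scatter)), so that change shows no clear direction. Nothing measured here accounts for either step. From the compounds shown here alone, whether a piperazin-1-yl group on the same aromatic carbon would stand with compound 2 or with compound 3 stays open. Also open, going by these compounds, is whether the exchange gives a similar step on the core of compound 1.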